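The source may report more compounds than this note shows. Statements on the series, on what has been measured and on what is new or still open speak of the compounds shown alone.

- Compound 1 `COC(=O)c1ccc(NC(=O)C2(C(=O)Nc3ccc(Nc4ncc5cc(C(=O)N(C)C)n(C6CCCC6)c5n4)cc3)CC2)cc1`: 92%
- Compound 2 `CN(C)C(=O)c1cc2cnc(Nc3ccc(NC(=O)C4(C(=O)Nc5ccccc5F)CC4)cc3)nc2n1C1CCCC1`: 88.6%

In a functional assay on A549 cells (Homo sapiens) for inhibition, read by CCK-8 assay, with a stated time of 72 h, tested at 10 uM (on this read-out higher numbers stand for more inhibition of growth at the one concentration tested and lower numbers for less inhibition of growth), compound 2 gives 88.6%, which lies within the scatter of compound 1 at 92%. Compound 3 `CN(C)C(=O)c1cc2cnc(Nc3ccc(NC(=O)C4(C(=O)Nc5ccc(Cl)c(C(F)(F)F)c5)CC4)cc3)nc2n1C1CCCC1` differs from compound 2 by 4-chloro-3-(trifluoromethyl)phenyl in place of 2-fluorophenyl on an amide-type nitrogen, with 4-chloro-3-(trifluoromethyl)phenyl in place of 2-fluorophenyl on an amide-type nitrogen. Among the compounds with values here, the only measured step at this place, a number 3.4 percentage points lower from compound 1 to compound 2 (within the scatter), is a single comparison and a narrow guide. On that basis, no change beyond the scatter is expected in this assay. The estimated step is a number 0.6 percentage points lower from compound 2 to compound 3 (within the scatter). Compound 3 is expected at 88%, within an estimated range of 75% to 98%.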

Compound 3, percent growth inhibition at one concentration: 88.1%
Estimate against measurement, compound 3: 0.1 percentage points below; low and high end bracket the measured number.
By their numbers in this assay, from the lowest: compounds 3, 2 and 1 (each within the scatter of the next).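

On the amide-type nitrogen, 4-chloro-3-(trifluoromethyl)phenyl now stands with 2-fluorophenyl and 4-(methoxycarbonyl)phenyl, and in this assay the result is a number 0.5 percentage points lower from compound 2 to compound 3 (within the scatter) and a number 3.9 percentage points lower from compound 1 to compound 3 (within the scatter). Within the data shown here, three differently substituted phenyl groups at this place thus give numbers that cannot be told apart, where the earlier compounds offered only a single comparison. No measurement at hand accounts for this sameness. Going by these compounds, all three groups are phenyl rings read at one concentration, so it remains open whether a cyclohexyl ring at this place, or a carboxylic acid or an amine on the phenyl ring, would keep these numbers.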